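What One Swapped Ring Group May Do

A few compounds are considered here, and "the series" means these few. Any claim that something is new, unique, unknown or untested is made for them only; others in the source may bear on it.

Going by the values given here, only two compounds have been measured so far, compound 1 `CC(=O)N1CCN(C(=O)[C@@H]2CC[C@@H](C)N2C(=O)C2=C(C(C)C)N3C(=N[C@@](C)(c4ccc(Cl)cc4)[C@H]3c3ccc(Cl)cc3)S2)C[C@H]1C` and compound 2 `CC(=O)N1CCN(C(=O)[C@@H]2CC[C@@H](C)N2C(=O)C2=C(C(C)C)N3C(=N[C@@](C)(c4ccc(Cl)cc4)[C@H]3c3ccc(Cl)cc3)S2)C[C@@H]1C`. Among the compounds with values here, in a physicochemical assay for solubility, read by HPLC, in phosphate buffer, at pH 6.8 (on this read-out higher numbers stand for higher solubility and lower numbers for lower solubility), compound 1 gives 72 ug/mL and compound 2 gives 75 ug/mL, so compound 2 stands level with its only neighbour, within the scatter of repeated measurements. Within the data shown here, the single measured step, a 1.0-fold higher number from compound 1 to compound 2 (0.02 log units; within the scatter), comes with the fact that compounds 1 and 2 differ only in the configuration as drawn. It therefore speaks about one change of configuration and not about replacing a whole group.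

Compound 3 `CC(C)C1=C(C(=O)N2[C@H](C)CC[C@H]2C(=O)N2CCN(C)C(C)(C)C2)SC2=N[C@@](C)(c3ccc(Cl)cc3)[C@@H](c3ccc(Cl)cc3)N21` keeps the shared core and differs from compound 2 in one place: a group of 9 heavy atoms (7 carbon, 2 nitrogen; one six-membered non-aromatic ring with 2 hetero atoms) in place of a group of 10 heavy atoms (7 carbon, 2 nitrogen, 1 oxygen; one six-membered non-aromatic ring with 2 hetero atoms), on a carbonyl carbon. Among the measured compounds shown here, no measured pair covers a swap of this kind, so the small size of a 1.0-fold higher number from compound 1 to compound 2 (0.02 log units; within the scatter) cannot simply be carried over, and the expectation here is a loose one. The expected change is a 2.4-fold higher number from compound 2 to compound 3 (0.38 log units; beyond the scatter), a modest rise in this assay, and this estimate is uncertain. For compound 3 the estimated value is 180 ug/mL, with an expected range from 60 ug/mL to 550 ug/mL.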

Compound 3, solubility: 30 ug/mL
The estimate for compound 3 lay 6.0-fold (0.78 log units) above the measured number; measured number below the stated range.
By their numbers in this assay, from the lowest: compound 3; then compounds 1 and 2 (each within the scatter of the next).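

In this assay, putting the group of 9 heavy atoms on the carbonyl carbon in place of the group of 10 heavy atoms gives a 2.5-fold lower number from compound 2 to compound 3 (0.40 log units; beyond the scatter), and the same swap gives a 2.4-fold lower number from compound 1 to compound 3 (0.38 log units; beyond the scatter). The two steps can be read as two views of one swap, agreeing in direction and nearly in size, because their starting points are almost the same molecule: the fact that compounds 1 and 2 differ only in the configuration as drawn. So this place on the carbonyl carbon is one where a change of group moves the number beyond the scatter, which the change of configuration alone did not do, although these numbers do not explain the fall.

The two groups differ in more than one way, including the oxygen atom and the defined stereocentre in the group that leaves, and the compounds shown do not tell which of these differences goes with the lower number. They also leave open how the number would read with a carboxylic acid or a simple amine on this carbonyl carbon in place of either six-membered ring.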